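This account rests on a few compounds, and the source may have more. Where it says the series, first, only, none or still open, it means among the compounds named here.

Measured so far:
Compound 1 `CCN(CC)C(=O)[C@@H]1CCCN(S(=O)(=O)c2ccc(S(=O)(=O)N(CC)CC)cc2)C1`: 6400 nM
Compound 2 `CCOC(=O)N1CCC[C@H](S(=O)(=O)c2ccc(S(=O)(=O)N(CC)CC)cc2)C1`: > 30000 nM

Both compounds were tested in a functional assay on MIA PaCa-2 cells (Homo sapiens) for inhibition, read by MTT assay, with a stated time of 7 days; on this read-out lower numbers stand for stronger inhibition and higher numbers for weaker inhibition. Compound 1 gives a number there, 6400 nM. Compound 2 gives > 30000 nM, which is a limit of the assay and not a number. Going by these compounds, compound 2 therefore stands at the limit of > 30000 nM in this assay, at which 1 of the 2 values shown sits, and its true position on the scale remains unknown.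

Compound 3 `CCOC(=O)N1CCC[C@@H](S(=O)(=O)c2ccc(S(=O)(=O)N(CC)CC)cc2)C1` is the next structure to consider. The change from compound 2 is the two compounds have the same atoms and bonds and differ only in configuration as drawn: 1 of 1 stereo elements differ; a stereocentre at a saturated ring carbon is drawn S in compound 2 and R in compound 3. Nothing is added or removed, and only the drawn configuration at that saturated ring carbon is reversed. Going by the values given here, no measured pair here isolates a change of this kind, so its usual size in this assay cannot be read from the data. Compound 2 offers only a limit as a starting point, so any step that can be read is expected to point towards stronger inhibition. A modest step or none beyond the scatter is the expectation, and compound 3 may well reach the same limit. The estimated change is an at least 1.2-fold lower number from compound 2 to compound 3 (0.07 log units; that floor lies within the scatter). For compound 3 the expected value is 25000 nM, with an estimated range from 8000 nM to 60000 nM.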

Compound 3, half-maximal inhibitory concentration: > 30000 nM
Compound 3 ended at the assay's limit (the forecaster's own chance of this, stated with the estimate: 55%); middle value at least 1.2-fold (0.07 log units) from the limit.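

In this assay compound 3 gives > 30000 nM, which is a limit of the assay and not a number. Compound 2 stands at a limit as well, so no step from compound 2 to compound 3 can be read: the limit of > 30000 nM in this assay, at which 2 of the 3 values shown sit.

The compounds shown leave open whether reversing the configuration at that saturated ring carbon changes inhibition at all.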